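Swapping One Phenyl on an Inactive Compound

The compounds below may be only part of what the source reports. "The series", "measured", "known", "first", "only" and "open" are said of these compounds alone.

- Compound 1 `COc1ccc(C2=C(c3cc(OC)c(OC)c(OC)c3)C(=O)CC2O)cc1O`: < 1 ug/mL (a limit)
- Compound 2 `COc1cc(C2=C(c3ccccc3)C(O[SiH2]C(C)(C)C)CC2=O)cc(OC)c1OC`: > 100 ug/mL (a limit)

Both compounds were tested for cytotoxicity in an ADME assay on HT-29 cells (Homo sapiens) for cytotoxicity, read by MTT assay, with a stated time of 72 h; on this read-out lower numbers stand for stronger inhibition and higher numbers for weaker inhibition. Neither result is an exact number. Compound 1 gives < 1 ug/mL, which is a limit of the assay. Compound 2 gives > 100 ug/mL, which is also a limit of the assay. Compound 2 therefore sits at the weak end of the two results, and compound 1 at the strong end.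

Compound 3 `COc1ccc(C2=C(c3cc(OC)c(OC)c(OC)c3)C(=O)CC2O[SiH2]C(C)(C)C)cc1O` is made from compound 2 by one change: 3-hydroxy-4-methoxyphenyl in place of phenyl on a double-bonded ring carbon. Among the measured compounds shown here, no measured step between closely matched compounds is available as a guide, so the expectation rests on a single comparison. Compound 1 carries the same 3-hydroxy-4-methoxyphenyl and gives < 1 ug/mL, a limit. The expected change an at least 50-fold lower number from compound 2 to compound 3 (1.69 log units; beyond the scatter) is therefore a large one towards stronger inhibition, well beyond the scatter. The result in this assay may again be only a limit. For compound 3 the estimate is 2 ug/mL, with an expected range from 0.2 ug/mL to 30 ug/mL.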

Compound 3, half-maximal inhibitory concentration: 38 ug/mL
The estimate for compound 3 lay 19-fold (1.28 log units) below the measured number; the whole stated range lies below it.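

Putting 3-hydroxy-4-methoxyphenyl in place of phenyl on a double-bonded ring carbon does shift the result: the swap gives an at least 2.6-fold lower number from compound 2 to compound 3 (0.42 log units; beyond the scatter) in this assay and the step has a limit at its weak end: the limit of > 100 ug/mL in this assay, at which 1 of the 3 values shown sits.

The second comparison shows that this swap alone does not bring compound 3 level with compound 1: a group of 5 heavy atoms (4 carbon, 1 silicon; no ring) in place of a hydrogen atom, on an oxygen on a saturated carbon, goes with an at least 38-fold higher number from compound 1 to compound 3 (1.57 log units; beyond the scatter) and this step has a limit at its strong end: the limit of < 1 ug/mL in this assay, at which 1 of the 3 values shown sits.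

Taken together, the two steps show that the result depends on both places, since the new phenyl group closes only part of the gap while the group on the oxygen still separates compound 3 from compound 1.

Whether the hydroxyl or the methoxy of the new group accounts for the shift stays open, and a simple 4-methoxyphenyl or 3-hydroxyphenyl at this position would help to separate them. Also open, on these data alone, is how a smaller group on the oxygen, such as methyl or acetyl, would compare with the hydrogen of compound 1 and the silicon group of compound 3.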